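The compounds below may be only part of what the source reports. "The series", "measured", "known", "first", "only" and "open" are said of these compounds alone.

Measured so far in an ADME assay:
compound 1 `O=S(=O)(Nc1ccccc1)c1ccc(Cl)cc1`, 8.47;
compound 2 `O=S(=O)(Nc1ccc(F)cc1)c1ccc(Cl)cc1`, 8.41;
compound 3 `Cc1ccc(NS(=O)(=O)c2ccc(Cl)cc2)cc1`, 8.78.

Compound 3 stands highest of the three: the step of a number 0.31 log units higher from compound 1 to compound 3 (beyond the scatter) and the step of a number 0.37 log units higher from compound 2 to compound 3 (beyond the scatter) both lie beyond the scatter, whereas a number 0.06 log units lower from compound 1 to compound 2 (within the scatter) does not. Compound 4 `Nc1ccc(NS(=O)(=O)c2ccc(Cl)cc2)cc1` differs from compound 3 by amino in place of methyl on an aromatic carbon. Going by the values given here, the steps that bear on this change are the two in which methyl entered, both modest rises in this assay. Amino has no precedent among the measured compounds, so the size is uncertain, but a further rise in this assay is expected for compound 4, estimated as a number 0.62 log units higher from compound 3 to compound 4 (beyond the scatter). Compound 4 is thus expected to give about 9.4 in this assay, within 8.9 to 9.9.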

Compound 4, acid dissociation constant: 9.76
Compound 4: the middle estimate sits 0.36 log units below what was measured; the measured number falls inside the stated range.
By their numbers in this assay, from the lowest: compounds 2 and 1 (each within the scatter of the next); then compound 3; then compound 4.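

In this assay, going by these compounds alone, the place para to a large group proves able to carry far more change than the earlier compounds showed: amino in place of methyl gives a number 0.98 log units higher from compound 3 to compound 4 (beyond the scatter). Measured against hydrogen and fluoro, amino gives a number 1.29 log units higher from compound 1 to compound 4 (beyond the scatter) and a number 1.35 log units higher from compound 2 to compound 4 (beyond the scatter), so this position spans a much wider range than the fluoro and methyl steps suggested. Nothing available explains the size of this rise.

From the compounds shown here alone, it remains open whether a dimethylamino or methoxy group would raise the number as far as amino does. Going by these compounds, whether a nitrile would lower it beyond the scatter is also open.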